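A few compounds are considered here, and "the series" means these few. Any claim that something is new, unique, unknown or untested is made for them only; others in the source may bear on it.

Three ureas built on one shared core have been tested in an ADME assay on HepG2 cells (Homo sapiens) for cytotoxicity, with a stated time of 72 h; on this read-out lower numbers stand for an effect already at smaller amounts and higher numbers for an effect only at larger amounts of compound. For the measured compounds named here, compound 2 `Cc1cc(NC(=O)Nc2cccc(Cl)c2)c2ccccc2n1` gives 19000 nM, one of only two plain numbers here. Compound 3 `Cc1cc(NC(=O)Nc2cccc(C(F)(F)F)c2)c2ccccc2n1` gives 21000 nM, and the step of a 1.1-fold higher number from compound 2 to compound 3 (0.04 log units; within the scatter) is within the scatter. Compound 1 `Cc1cc(NC(=O)Nc2ccc(C)c(Cl)c2)c2ccccc2n1` reports only a limit, > 25000 nM, so that the limit of > 25000 nM in this assay, at which 1 of the 3 values shown sits, holds for it. The step of an at least 1.3-fold lower number from compound 1 to compound 2 (0.11 log units; that floor lies within the scatter) is likewise small. Compound 4 `Cc1cc(NC(=O)Nc2ccccc2N)c2ccccc2n1` is not yet measured; it differs from compound 2 by 2-aminophenyl in place of 3-chlorophenyl on an amide-type nitrogen. Neither measured step concerns this exchange of one aryl group for another, and both were modest, so no shift beyond the scatter is expected. Compound 4 is therefore estimated at 20000 nM, between 8000 nM and 50000 nM. For compound 4 this means an expected step of a 1.1-fold higher number from compound 2 to compound 4 (0.02 log units; within the scatter).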

Compound 4, half-maximal effective concentration: > 25000 nM
Compound 4: no number, only a limit; the forecaster's own chance of this, stated with the estimate: 40%; at least 1.2-fold (0.09 log units) between middle value and limit.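

Replacing 3-chlorophenyl with 2-aminophenyl on the amide-type nitrogen exchanges a whole aryl group, and it gives an at least 1.3-fold higher number from compound 2 to compound 4 (0.11 log units; that floor lies within the scatter). Going by these compounds, compound 4 reports only a limit, not a number, so the true size of this step stays unknown. In this assay, the new aryl group joins compound 1 at the same limit: the limit of > 25000 nM in this assay, at which 2 of the 4 values shown sit.

The compounds shown leave open how 3-aminophenyl or 2-chlorophenyl would read here, which would separate the effect of the group from that of its place on the ring. They also leave open what a carboxylic acid in place of the amine would give.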